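Chain extension on the shared core: cytotoxicity notes

The source may hold more compounds than are shown below. What is called first, only, known or untested is meant among the compounds shown, and "the series" means these compounds.

Measured so far:
compound 1 `CCCCCc1ccc(-c2cc3cn([C@H]4C[C@H](O)[C@@H](CO)O4)c(=O)nc3o2)nc1` — > 100000 nM
compound 2 `O=c1nc2oc(C#Cc3ccccc3)cc2cn1[C@H]1C[C@H](O)[C@@H](CO)O1` — > 570000 nM
compound 3 `CCCCCCc1ccc(-c2cc3cn([C@H]4C[C@H](O)[C@@H](CO)O4)c(=O)nc3o2)cn1` — 100000 nM

In an ADME assay on HEL cells (Homo sapiens) for cytotoxicity, with a stated time of 3 days (a higher number here means that more compound is tolerated, a lower number that less compound is tolerated), compound 1 reaches only a limit, > 100000 nM, which is the limit of > 100000 nM in this assay, at which 1 of the 3 values shown sits, and not a measured number. Compound 2 likewise stops at a limit, > 570000 nM, which is the limit of > 570000 nM in this assay, at which 1 of the 3 values shown sits. Compound 3 gives 100000 nM in this assay, a number rather than a limit. Compound 1 therefore stands at a limit, tolerated up to the highest concentration tested, with one of the other values also a limit.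

Compound 4 `CCCCCCc1ccc(-c2cc3cn([C@H]4C[C@H](O)[C@@H](CO)O4)c(=O)nc3o2)nc1` differs from compound 1 by methyl in place of hydrogen on a saturated chain carbon, five bonds along the chain from an aromatic carbon. Among the compounds with values here, no pair of measured compounds shows the effect of such a change. The expected step is a number no higher from compound 1 to compound 4 (the limit leaves the size open), nothing beyond the scatter, and a limit is again likely. Compound 4 is estimated at 100000 nM, within 30000 nM to 300000 nM.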

Compound 4, minimum cytotoxic concentration: > 100000 nM
Compound 4 ended at the assay's limit; the forecaster's own chance of this, stated with the estimate: 60%; the middle value sits exactly at the limit.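

Compound 1 and compound 4 both end at a limit in this assay, so the step between them cannot be read. The compounds shown leave open what methyl in place of hydrogen does to the tolerated concentration.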